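The source may report more compounds than this note shows. Statements on the series, on what has been measured and on what is new or still open speak of the compounds shown alone.

Series notes, salicylanilide set

Compound 1 `N#Cc1ccc(NC(=O)c2cc(F)ccc2O)cc1` and compound 3 `N#Cc1ccc(NC(=O)c2cc(Cl)ccc2O)cc1` share one core; compound 2 `O=C(Nc1ccc(OC(F)(F)F)c(Cl)c1)c1cc(F)ccc1O` and the unmeasured compound 4 `O=C(Nc1ccc(OC(F)(F)F)c(Cl)c1)c1cc(Cl)ccc1O` share another. How the core of compound 1 differs from the core of compound 2 is not broken down here.

In a functional assay on HL-60 cells (Homo sapiens) for cytotoxicity, read by luminescence and CellTiter-Glo, with a stated time of 3 days (on this read-out lower numbers stand for stronger inhibition and higher numbers for weaker inhibition), compound 1 gives 1420 nM. Compound 3 gives 700 nM in this assay. The change between them is chloro in place of fluoro on an aromatic carbon and it made a step of a 2.0-fold lower number from compound 1 to compound 3 (0.31 log units; beyond the scatter).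

In this assay compound 2 gives 550 nM. Compound 4 carries the same change on the other core: chloro in place of fluoro on an aromatic carbon. The place around the change reads the same in both pairs, so this is the same change, seen twice among the compounds here.

For the measured compounds named here, from compound 2 to compound 4 a step of about a 1.8-fold lower number from compound 2 to compound 4 (0.26 log units; within the scatter) is expected, set beside the measured step from compound 1 to compound 3, because the single precedent is a 2.0-fold lower number from compound 1 to compound 3 (0.31 log units; beyond the scatter). One precedent is a thin basis, so the range is kept wide. For compound 4 the expected value in this assay is 300 nM, between 150 nM and 650 nM.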

Compound 4, half-maximal inhibitory concentration: 450 nM
Estimate against measurement, compound 4: 1.5-fold (0.18 log units) below, within the range that was stated.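

Working reading: in this assay, chloro in place of fluoro on an aromatic carbon, para to a hydroxy group, gives a 1.2-fold lower number from compound 2 to compound 4 (0.09 log units; within the scatter), so on the core of compound 2 the step cannot be told apart from repeat-measurement noise. Set beside the earlier step, the result shows no measurable disagreement between the two cores: the same change on two cores in this assay, a 2.0-fold lower number (0.31 log units; beyond the scatter) from compound 1 to compound 3 and a 1.2-fold lower number (0.09 log units; within the scatter) from compound 2 to compound 4, 1.7-fold (0.22 log units) apart, within the scatter of two such steps. The change can therefore be carried from the core of compound 1 to the core of compound 2 without any sign of a different step, but one pair per core does not show that the two steps are equal, nor does it establish a real effect of the change on the second core.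

The compounds shown leave open what a bromo or a methoxy group would give at this same place. Also open, from the compounds shown here alone, is whether the step holds on a core with a carboxylic acid in place of the nitrile.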